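The compounds below may be only part of what the source reports. "The series", "measured", "known", "first", "only" and "open" are said of these compounds alone.

Compound 1 `CCn1c(-c2ccccc2)nc2c(NC3CCCCC3)ncnc21`, compound 2 `Cn1c(-c2cccc(Cl)c2)nc2c(NC3CCCC3)ncnc21` and compound 3 `CCCn1c(-c2ccccc2)nc2c(NC3CCC3)ncnc21` share one core and differ in the group on the five-membered ring and in the cycloalkylamine. In an assay on CHO cells for displacement of a labelled ligand from adenosine receptor A3 (Homo sapiens), read by scintillation counting, with a stated time of 3 h (on this read-out higher numbers stand for weaker inhibition and lower numbers for stronger inhibition), compound 1 gives 707 nM, compound 2 gives 514 nM and compound 3 gives 264 nM; all three numbers lie within the scatter of one another, so compound 2 stands among them without a clear separation. Compound 4 `Cc1ccccc1-c1nc2c(NC3CCCC3)ncnc2n1C` follows compound 2 with one change: 2-methylphenyl in place of 3-chlorophenyl on an aromatic carbon. Going by the values given here, no measured pair shows this change, so the step from compound 2 to compound 4 is expected to be small, a 1.6-fold higher number from compound 2 to compound 4 (0.19 log units; within the scatter), in either direction or none beyond the scatter. Compound 4 is therefore estimated at 800 nM in this assay, with a range from 250 nM to 2500 nM.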

Compound 4, inhibition constant: 3000 nM
Compound 4: the middle estimate sits 3.8-fold (0.57 log units) below what was measured; measured number outside the range, above it.
By their numbers in this assay, from the lowest: compounds 3, 2 and 1 (each within the scatter of the next, the first and the last beyond it); then compound 4.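

Going by these compounds alone, replacing 3-chlorophenyl with 2-methylphenyl on the aromatic carbon between two ring nitrogen atoms gives the first single-place comparison in this set: in this assay, it produces a 5.8-fold higher number from compound 2 to compound 4 (0.77 log units; beyond the scatter). This position therefore distinguishes between these two substituted phenyl groups, although each has 7 heavy atoms and neither has hydrogen-bond donors or acceptors. No evidence is available to explain the size of this step.

The compounds shown do not separate the identity of the substituent from its place on the phenyl ring. A compound bearing 3-methylphenyl or 2-chlorophenyl here would address that question.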